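The source may hold more compounds than are shown below. What is called first, only, known or untested is meant among the compounds shown, and "the series" means these compounds.

Compound 1 `O=C(/C=C/c1cn(-c2ccccc2)nc1-c1cccnc1)c1ccsc1` and compound 2 `COc1cc(OC)c(C(=O)/C=C/c2cn(-c3ccccc3)nc2-c2cccnc2)c(OC)c1` share a core; the difference between the two cores is not broken down here. In a functional assay on MCF7 cells (Homo sapiens) for inhibition, read by sulforhodamine B assay, with a stated time of 72 h (a higher number here means a weaker inhibitor, a lower number a stronger inhibitor), compound 1 gives 500 nM, and compound 2 gives 1000 nM. Compound 3 `O=C(/C=C/c1cn(-c2ccccc2)nc1-c1ccncc1)c1ccsc1` carries pyridin-4-yl in place of pyridin-3-yl on an aromatic carbon; in this assay compound 3 gives 1500 nM, which is a 3.0-fold higher number from compound 1 to compound 3 (0.48 log units; beyond the scatter). Compound 4 `COc1cc(OC)c(C(=O)/C=C/c2cn(-c3ccccc3)nc2-c2ccncc2)c(OC)c1` awaits measurement and carries pyridin-4-yl in place of pyridin-3-yl on an aromatic carbon. This is the same kind of change as that from compound 1 to compound 3, with one difference around the place: the ring atom that bears a large group in compound 2 bears a group of 9 heavy atoms in compound 1. The step is expected to be a 3.0-fold higher number from compound 2 to compound 4 (0.48 log units; beyond the scatter), because the earlier change gave a 3.0-fold higher number from compound 1 to compound 3 (0.48 log units; beyond the scatter). Compound 4 is estimated at 3000 nM, between 1500 nM and 6000 nM.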

Compound 4, half-maximal inhibitory concentration: 1600 nM
Compound 4: the middle estimate sits 1.9-fold (0.27 log units) above what was measured; the measured number falls inside the stated range.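

Pyridin-4-yl in place of pyridin-3-yl on the core of compound 2 gives a 1.6-fold higher number from compound 2 to compound 4 (0.20 log units; within the scatter) in this assay, so this step alone cannot separate the two compounds. Set beside the step on the core of compound 1, it does not differ measurably: the same change on two cores in this assay, a 3.0-fold higher number (0.48 log units; beyond the scatter) from compound 1 to compound 3 and a 1.6-fold higher number (0.20 log units; within the scatter) from compound 2 to compound 4, 1.9-fold (0.27 log units) apart, within the scatter of two such steps. Within the data shown here, this agrees with the change carrying across these two cores, but two pairs in one assay do not show that it carries to other cores, and they do not fix its size, as only one of the two steps lies beyond the scatter.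

Open, as far as these compounds go, is how an amine or a carboxylic acid on the ring at that place would compare with either pyridinyl group. Also open, from the compounds shown here alone, is whether the step holds on any core beyond these two.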